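The source may hold more compounds than are shown below. What is called first, only, known or untested is meant among the compounds shown, and "the series" means these compounds.

Within the data shown here, compound 2 `Cc1cn([C@@H]2O[C@H](CO[Si](C)(C)C(C)(C)C)[C@@]3(OS(=O)(=O)C=C3NC(=O)Nc3ccccc3)[C@H]2O[Si](C)(C)C(C)(C)C)c(=O)n(C)c1=O` is one of two compounds measured in an ADME assay on HEL cells (Homo sapiens) for cytotoxicity, with a stated time of 3 days (a higher number here means that more compound is tolerated, a lower number that less compound is tolerated), and, in this assay, compound 2 gives 1400 nM. Compound 1 `Cc1cn([C@@H]2O[C@H](CO[Si](C)(C)C(C)(C)C)[C@@]3(OS(=O)(=O)C=C3NC(=O)NC(=O)c3ccccc3)[C@H]2O[Si](C)(C)C(C)(C)C)c(=O)n(C)c1=O` gives only a limit of the assay in this assay, >= 80000 nM. Among the measured compounds shown here, the one measured step, an at least 57-fold lower number from compound 1 to compound 2 (1.75 log units; beyond the scatter), shows that a change on this amide-type nitrogen can move the number strongly. Compound 3 `Cc1cn([C@@H]2O[C@H](CO[Si](C)(C)C(C)(C)C)[C@@]3(OS(=O)(=O)C=C3NC(=O)NCc3ccccc3)[C@H]2O[Si](C)(C)C(C)(C)C)c(=O)n(C)c1=O` carries a smaller change at that place: benzyl in place of phenyl on an amide-type nitrogen. For the measured compounds named here, no measured step tests a benzyl here, so the expected step is a 1.4-fold higher number from compound 2 to compound 3 (0.15 log units; within the scatter), near or within the scatter. Compound 3 is therefore estimated at 2000 nM, between 400 nM and 20000 nM.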

Compound 3, minimum cytotoxic concentration: 4000 nM
Beside the measured number, compound 3's estimate is 2.0-fold (0.30 log units) below it, within the range that was stated.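

Benzyl on this amide-type nitrogen brings a 2.9-fold higher number from compound 2 to compound 3 (0.46 log units; beyond the scatter) in this assay, so even a change much smaller than removing the benzoyl carbonyl moves the number here. Benzyl still sits far from benzoyl, with an at least 20-fold lower number from compound 1 to compound 3 (1.30 log units; beyond the scatter). Compound 1 is a limit of the assay, so that step gives only a bound: the limit of >= 80000 nM in this assay, at which 1 of the 3 values shown sits.

Going by these compounds, whether a longer chain, such as phenylethyl, on this nitrogen would raise the number further stays open. So does the effect of a group with no aromatic ring there, such as a plain butyl chain.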